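A Biphenyl Ketone Joins a Weakly Active Series

The source may hold more compounds than are shown below. What is called first, only, known or untested is meant among the compounds shown, and "the series" means these compounds.

Among the compounds with values here, compound 2, with the structure `COc1cc(-c2nnc3n2NC(c2ccco2)C(C(=O)c2ccc(F)c(F)c2)S3)cc(OC)c1OC`, is the only member of this small set to give an actual number in a functional assay on PC-3 cells (Homo sapiens) for cytotoxicity, read by MTT assay, with a stated time of 48 h; a higher number here means a weaker inhibitor, a lower number a stronger inhibitor. In this assay compound 2 gives 36000 nM. Its neighbour compound 1, with the structure `COc1cc(-c2nnc3n2NC(c2ccco2)C(C(=O)c2ccccc2F)S3)cc(OC)c1OC`, differs only in the ring attached to the carbonyl carbon. For compound 1 the assay reports only a limit, > 100000 nM, a situation summarised as the limit of > 100000 nM in this assay, at which 1 of the 2 values shown sits. The move from that limit to the number for compound 2 is an at least 2.7-fold lower number from compound 1 to compound 2 (0.44 log units; beyond the scatter), a step toward stronger inhibition that still leaves both compounds weak.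

Compound 3, with the structure `COc1cc(-c2nnc3n2NC(c2ccco2)C(C(=O)c2ccc(-c4ccccc4)cc2)S3)cc(OC)c1OC`, continues the same line of variation: 4-phenylphenyl in place of 3,4-difluorophenyl on a carbonyl carbon. Within the data shown here, the one measured step bears on it only in showing that swapping the ring on the carbonyl carbon shifted the read-out modestly; the new ring shares nothing with either fluorinated one, so no direction can be borrowed. The expected step of a 1.4-fold lower number from compound 2 to compound 3 (0.16 log units; within the scatter) is therefore set near zero, within the scatter. Compound 3 is estimated at 25000 nM, with a range from 6000 nM to 100000 nM.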

Compound 3, half-maximal inhibitory concentration: 45900 nM
For compound 3 the middle estimate is 1.8-fold (0.26 log units) below the measured one, and the stated range covers the measured number.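

Replacing 3,4-difluorophenyl with the larger 4-phenylphenyl on this carbonyl carbon gives a 1.3-fold higher number from compound 2 to compound 3 (0.11 log units; within the scatter) in this assay, so the two compounds cannot be told apart, even though the entering group has a second aromatic ring and no fluorine. Measured against 2-fluorophenyl, the same group gives an at least 2.1-fold lower number from compound 1 to compound 3 (0.33 log units; beyond the scatter), which shows that a ring carrying no fluorine can also give a measurable number in this series, so fluorine on this ring is not required for one. That step starts from a limit rather than a number, the one held by compound 1: the limit of > 100000 nM in this assay, at which 1 of the 3 values shown sits.

On these data alone, all three groups at this position are carbon-only aromatic rings, with or without fluorine, so the effect of an amine, a carboxylic acid or a short alkyl chain in the same place remains open. All the readings also come from this one cell assay and all remain weak, leaving open whether any change on this carbonyl carbon could give much stronger inhibition.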